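This account rests on a few compounds, and the source may have more. Where it says the series, first, only, none or still open, it means among the compounds named here.

Compound 1 `CCCC(=O)OCSc1ccc(OC)cc1C(=O)NCCC(N)=O` in an ADME assay on CEM-SS cells (Homo sapiens) for cytotoxicity, read by XTT assay, with a stated time of 6 days (a higher number here means that more compound is tolerated, a lower number that less compound is tolerated), gives > 100 uM.
Compound 2 `CCCC(=O)OCSc1ccccc1C(=O)NCCCCCC(N)=O` gives 16.3 uM.
Compound 3 `CCCC(=O)OC[Se]c1ccccc1C(=O)NCCC(N)=O` gives 10.5 uM.

The value for compound 1 is a limit of the assay, not a number. Of the two compounds that give a number, compound 2 and compound 3 sit within the usual scatter of each other, so no order between them can be read from these values. Going by the values given here, the three compounds differ from one another in more than one place, and no single-change step between measured compounds is available.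

Compound 4 `CCCC(=O)OCSc1ccccc1C(N)=O` has not yet been measured. It differs from compound 2 in one place: hydrogen in place of 5-carbamoylpentyl on an amide-type nitrogen. The chain that leaves carries a second amide group, and what remains is the smaller primary amide on the shared core.

Among the compounds with values here, with no comparable step among the measured compounds, the direction of the change is uncertain; a step of modest size, in either direction, or none beyond the scatter, is expected from compound 2 to compound 4 as a 1.5-fold higher number from compound 2 to compound 4 (0.19 log units; within the scatter). Compound 4 is estimated to give 25 uM, in a range from 8 uM to 100 uM.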

Compound 4, half-maximal toxic concentration: 12.4 uM
Estimate against measurement, compound 4: 2.0-fold (0.30 log units) above; the range from low to high includes it.
By their numbers in this assay, from the lowest: compounds 3, 4 and 2 (each within the scatter of the next). At a limit, above all of these: compound 1.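

Replacing the 5-carbamoylpentyl chain on the amide-type nitrogen with hydrogen gives in this assay a 1.3-fold lower number from compound 2 to compound 4 (0.12 log units; within the scatter) and so stays within the scatter. This is the first single-change step among these compounds, and it shows that this whole chain, with its second amide group, can leave this nitrogen without a change in the number that can be told from the scatter. Nothing measured here gives a reason for this result.

Going by these compounds, it remains open whether another group on this nitrogen, such as a chain ending in an amine or a carboxylic acid, would also stay within the scatter of these numbers. Compound 1 and compound 3 each differ from compound 4 in more than one place, so neither can settle what this nitrogen tolerates.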